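Swapping 4-methylpiperazin-1-yl for methyl on a shared core

The compounds below may be only part of what the source reports. "The series", "measured", "known", "first", "only" and "open" are said of these compounds alone.

Compound 1 `CN(C(=O)CNC(=O)CN1CCCCC1)c1ccc(Cl)cc1C(=O)c1ccccc1Cl`: > 100 mg/kg (a limit)
Compound 2 `CCCCCC(=O)NCC(=O)N(C)c1ccc(Cl)cc1C(=O)c1ccccc1Cl`: 90 mg/kg
Compound 3 `CN1CCN(CC(=O)NCC(=O)N(C)c2ccc(Cl)cc2C(=O)c2ccccc2Cl)CC1`: > 100 mg/kg (a limit)

In a functional assay on the whole organism with Mus musculus as the target, in the rotarod test (on this read-out higher numbers stand for an effect only at larger amounts of compound and lower numbers for an effect already at smaller amounts), compound 3 gives > 100 mg/kg, which is a limit and not a number. It sits at the limit of > 100 mg/kg in this assay, at which 2 of the 3 values shown sit. Compound 4 `CCC(=O)NCC(=O)N(C)c1ccc(Cl)cc1C(=O)c1ccccc1Cl` differs from compound 3 by methyl in place of 4-methylpiperazin-1-yl on a saturated chain carbon bound to a carbonyl carbon. The closest measured evidence is an at least 1.1-fold higher number from compound 2 to compound 3 (0.04 log units; that floor lies within the scatter), with an at least 1.1-fold lower number from compound 1 to compound 2 (0.04 log units; that floor lies within the scatter) alongside it. For the measured compounds named here, compound 2, the only compound here with an unbranched chain and a real number, gives 90 mg/kg. A lower number is therefore expected in this assay, though its size remains uncertain. The expected step is an at least 1.1-fold lower number from compound 3 to compound 4 (0.04 log units; that floor lies within the scatter). Compound 4 is estimated at 90 mg/kg, with an expected range of 35 mg/kg to 230 mg/kg.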

Compound 4, dose for half-maximal effect: 36 mg/kg
Compound 4: the middle estimate sits 2.5-fold (0.40 log units) above what was measured, within the range that was stated.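

Methyl in place of 4-methylpiperazin-1-yl on a saturated chain carbon bound to a carbonyl carbon gives, in this assay, the first step here beyond the scatter: an at least 2.7-fold lower number from compound 3 to compound 4 (0.44 log units; beyond the scatter). Methyl in place of piperidin-1-yl gives an at least 2.7-fold lower number from compound 1 to compound 4 (0.44 log units; beyond the scatter), and hydrogen in place of propyl shows that chain length alone also shifts the read-out, with a 2.5-fold lower number from compound 2 to compound 4 (0.40 log units; beyond the scatter). Compound 1 and compound 3 remain limits and not numbers: the limit of > 100 mg/kg in this assay, at which 2 of the 4 values shown sit.

As far as these compounds go, whether a butyl-free chain such as acetyl, or an open-chain amine such as dimethylamino, would continue this direction stays open.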